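A few compounds are considered here, and "the series" means these few. Any claim that something is new, unique, unknown or untested is made for them only; others in the source may bear on it.

Of the compounds shown here, three have been read in a physicochemical assay for solubility, at pH 6.5; a lower number here means a less soluble compound, a higher number a more soluble compound. Compound 1 `CS(=O)(=O)c1ccc(-c2cnc3ccc(-c4cccc(C(=O)NCCO)c4)nn23)cc1` gives > 100000 nM, which is a limit of the assay and not a number. Compound 2 `CS(=O)(=O)c1ccc(-c2cnc3ccc(-c4cccc(C(=O)N5CCC(O)CC5)c4)nn23)cc1` gives 178000 nM. Compound 3 `C[S+]([O-])c1cccc(-c2ccc3ncc(-c4ccc(S(C)(=O)=O)cc4)n3n2)c1` gives 157000 nM, and this value lies within the scatter of the value for compound 2. Two steps carry no readable size: a step that the limit leaves unreadable from compound 1 to compound 2 and a step that the limit leaves unreadable from compound 1 to compound 3.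

Compound 4 `C[S+]([O-])c1ccc(-c2cnc3ccc(-c4cccc([S+](C)[O-])c4)nn23)cc1` differs from compound 3 in one place, on an aromatic carbon of a six-membered aromatic ring of carbon only, para to a large group: a group of 3 heavy atoms (1 carbon, 1 oxygen, 1 sulfur; no ring) in place of a group of 4 heavy atoms (1 carbon, 2 oxygen, 1 sulfur; no ring), on an aromatic carbon. Methylsulfonyl leaves at that place.

Within the data shown here, no measured step makes this exact exchange. The nearest is the step that brings the same entering group onto an aromatic carbon in place of a larger group: a 1.1-fold lower number from compound 2 to compound 3 (0.05 log units; within the scatter). On that single readable step, no change beyond the scatter is expected in this assay, though one step is thin support. The estimated step is a 1.0-fold higher number from compound 3 to compound 4 (0.01 log units; within the scatter). For compound 4 the expected value is 160000 nM, with an estimated range of 70000 nM to 400000 nM. A report as a limit, as happened with compound 1, remains possible.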

Compound 4, solubility: 192000 nM
For compound 4 the middle estimate is 1.2-fold (0.08 log units) below the measured one, and the stated range covers the measured number.
By their numbers in this assay, from the lowest: compounds 3, 2 and 4 (each within the scatter of the next).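

In this assay, the exchange at this position, on an aromatic carbon of a six-membered aromatic ring of carbon only, para to a large group, puts the group of 3 heavy atoms (1 carbon, 1 oxygen, 1 sulfur) in place of methylsulfonyl and gives a 1.2-fold higher number from compound 3 to compound 4 (0.09 log units; within the scatter). Among these compounds, the only earlier readable step, a 1.1-fold lower number from compound 2 to compound 3 (0.05 log units; within the scatter), brought the same group in at a different place, so a step within the scatter has now been seen at both places, and compound 4 carries this group at both. The steps from compound 1 cannot be read, as its value is a limit and not a number: the limit of > 100000 nM in this assay, at which 1 of the 4 values shown sits.

On these data alone, how an amine, a carboxylic acid or a longer chain at this position would read in this assay remains open. With one readable step at this position, and the group of 3 heavy atoms as the only replacement for methylsulfonyl, no trend for this position can be drawn from these compounds.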